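Solubility notes: aromatic substituent swap on the shared core

The source may hold more compounds than are shown below. What is called first, only, known or untested is meant among the compounds shown, and "the series" means these compounds.

The series shares one core and varies a single aromatic substituent on it. Compound 1 `Cc1cc(NCc2ccccn2)n2ncc(-c3cccc(F)c3)c2n1` carries a 3-fluorophenyl there. In a physicochemical assay for solubility, read by HPLC, using the shake flask method, measured as kinetic solubility, with a stated time of 2 h, at pH 7.4 (a lower number here means a less soluble compound, a higher number a more soluble compound), compound 1 gives 5000 nM. Compound 2 `Cc1cc(NCc2ccccn2)n2ncc(-c3c(C)cccc3C)c2n1` carries a 2,6-dimethylphenyl in its place. In this assay compound 2 gives only a limit, < 5000 nM. The step of a number no higher from compound 1 to compound 2 (the limit leaves the size open) accordingly has no readable size, as the limit of < 5000 nM in this assay, at which 1 of the 2 values shown sits, shows. Compound 3 `Cc1cc(NCc2ccccn2)n2ncc(-c3ccn(C)n3)c2n1` is the next member: 1-methyl-1H-pyrazol-3-yl in place of 2,6-dimethylphenyl on an aromatic carbon. Within the data shown here, no measured step covers this change directly. Among the measured compounds shown here, the only measured step, a number no higher from compound 1 to compound 2 (the limit leaves the size open), concerns a different swap at the same place and its size is not readable, so it sets neither direction nor size for this assay here. With compound 2 standing at a limit, the step to compound 3 is open in both directions. Compound 3 is expected to give 10000 nM, within 2500 nM to 40000 nM. The step of an at least 2.0-fold higher number from compound 2 to compound 3 (0.30 log units; that floor lies within the scatter) is therefore an estimate only.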

Compound 3, solubility: 188000 nM
For compound 3 the middle estimate is 19-fold (1.27 log units) below the measured one; the whole stated range lies below it.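

Among these compounds, the swap from 3-fluorophenyl to 1-methyl-1H-pyrazol-3-yl gives the first step of readable size at this place on the shared core, a 38-fold higher number from compound 1 to compound 3 (1.58 log units; beyond the scatter). The step of an at least 37-fold higher number from compound 2 to compound 3 (1.57 log units; beyond the scatter) has only a floor for its size, as compound 2 stands at a limit: the limit of < 5000 nM in this assay, at which 1 of the 3 values shown sits. Compound 1 and compound 2 both carry a six-membered aromatic ring of carbon only and both give lower numbers than compound 3, which carries a five-membered aromatic ring with 2 hetero atoms.

The compounds shown do not separate the effect of ring size from that of the ring nitrogens or the methyl group on the pyrazole. From the compounds shown here alone, how a pyridine ring, a morpholine or a carboxylic acid at this place would read in this assay remains open.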